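This account rests on a few compounds, and the source may have more. Where it says the series, first, only, none or still open, it means among the compounds named here.

Measured so far:
compound 1, `COc1ccc(S(=O)(=O)NCCN2CCC(CCC(=O)c3cc(Cl)c(N)cc3OC)CC2)cc1`, in an assay on brain for displacement of a labelled ligand from 5-hydroxytryptamine receptor 4 (Cavia porcellus), with a stated time of 30 min, in the presence of a further agent that is not named here; on this read-out higher numbers stand for weaker inhibition and lower numbers for stronger inhibition: 12.3 nM
compound 2, `COc1cc(N)c(Cl)cc1C(=O)CCC1CCN(CCNS(=O)(=O)c2ccc(C)cc2)CC1`, in this assay: 18 nM
compound 3, `COc1ccc(S(=O)(=O)NCCN2CCC(CCC(=O)c3cc(Cl)c(N)cc3OC)CC2)c(OC)c1`, in this assay: 18.7 nM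

The three numbers cannot be told apart: from compound 2 to compound 3 the step is a 1.0-fold higher number from compound 2 to compound 3 (0.02 log units; within the scatter), and from compound 1 to compound 3 it is a 1.5-fold higher number from compound 1 to compound 3 (0.18 log units; within the scatter), so compound 3 stands level with the other two.

Compound 4, `COc1cc(N)c(Cl)cc1C(=O)CCC1CCN(CCNS(=O)(=O)c2cc(Br)c(N)c(Br)c2)CC1`, is not yet measured. It differs from compound 3 at the sulfonyl aryl group: 4-amino-3,5-dibromophenyl in place of 2,4-dimethoxyphenyl on a sulfonyl sulfur. Within the data shown here, the only step at this position so far, from compound 2 to compound 3 a 1.0-fold higher number from compound 2 to compound 3 (0.02 log units; within the scatter), was within the scatter, as was the substituent change from compound 1 to compound 2 a 1.5-fold higher number from compound 1 to compound 2 (0.17 log units; within the scatter). Among the measured compounds shown here, no change at this group has yet moved the number in this assay, and the new group has no measured precedent. The expected step from compound 3 to compound 4 in this assay is therefore a 1.0-fold lower number from compound 3 to compound 4 (0.02 log units; within the scatter), none beyond the scatter. Compound 4 is estimated at 18 nM in this assay, within 6 nM to 55 nM.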

Compound 4, inhibition constant: 8.7 nM
Beside the measured number, compound 4's estimate is 2.1-fold (0.32 log units) above it, within the range that was stated.
By their numbers in this assay, from the lowest: compounds 4, 1, 2 and 3 (each within the scatter of the next, the first and the last beyond it).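

The sulfonyl aryl group now shows a change that moves the number in this assay beyond the scatter: 4-amino-3,5-dibromophenyl gives a 2.1-fold lower number from compound 3 to compound 4 (0.33 log units; beyond the scatter) and a 2.1-fold lower number from compound 2 to compound 4 (0.32 log units; beyond the scatter), both modest. This holds against only two of the three aryl groups, and compound 1 goes against it: the 4-methoxyphenyl group stays level with the new group, at a 1.4-fold lower number from compound 1 to compound 4 (0.15 log units; within the scatter), so the position does not yet show a clear order among its groups. Nothing shown gives a reason for these steps.

The compounds shown do not separate the amine from the two bromine atoms, so a phenyl group carrying only the amine or only the bromines would be needed to assign the step. Going by these compounds, whether the sulfonyl sulfur needs an aromatic ring at all also stays open, and a cyclohexyl group there would test it.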